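The source may report more compounds than this note shows. Statements on the series, on what has been measured and on what is new or still open speak of the compounds shown alone.

Three compounds share one core and differ only in the group on a saturated chain carbon bound to a nitrogen on an aromatic ring. In a physicochemical assay for solubility, read by HPLC, using the shake flask method, measured as kinetic solubility, with a stated time of 2 h, at pH 7.4 (on this read-out lower numbers stand for lower solubility and higher numbers for higher solubility), compound 1 `Cc1cc(NCc2ccncc2)n2nc(C)c(-c3ccccc3)c2n1` gives 134000 nM. In this assay compound 2 `Cc1cc(NCc2c[nH]cn2)n2nc(C)c(-c3ccccc3)c2n1` gives 14600 nM. Compound 3 `Cc1cc(NCc2ccco2)n2nc(C)c(-c3ccccc3)c2n1` reaches only a limit of the assay in this assay, recorded as < 5000 nM. Compound 3 therefore stands at the limit of < 5000 nM in this assay, at which 1 of the 3 values shown sits, the lowest point among the numbers shown. The steps leading to it were an at least 26-fold lower number from compound 1 to compound 3 (1.42 log units; beyond the scatter) and an at least 2.9-fold lower number from compound 2 to compound 3 (0.46 log units; beyond the scatter), while a 9.2-fold lower number from compound 1 to compound 2 (0.96 log units; beyond the scatter). Compound 4 `Cc1cc(NCc2cccs2)n2nc(C)c(-c3ccccc3)c2n1` differs from compound 3 in one place: thiophen-2-yl in place of furan-2-yl on a saturated chain carbon bound to a nitrogen on an aromatic ring. Within the data shown here, no measured step exchanges furan-2-yl for thiophen-2-yl, so the two steps into compound 3 fix only the starting point and carry no information on the direction of this change. The step from compound 3 to compound 4 is therefore expected to stay within the scatter, as a step that the limit leaves unreadable from compound 3 to compound 4, most likely leaving compound 4 at the limit again. Compound 4 is estimated at 2500 nM, with a range from 500 nM to 8000 nM.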

Compound 4, solubility: < 5000 nM
Compound 4: no number, only a limit; the forecaster's own chance of this, stated with the estimate: 75%; the middle value does not contradict the limit.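

In this assay, thiophen-2-yl on a saturated chain carbon bound to a nitrogen on an aromatic ring gives, as furan-2-yl does, a limit of the assay and not a number: the limit of < 5000 nM in this assay, at which 2 of the 4 values shown sit. The step between compound 3 and compound 4 therefore cannot be read, and this exchange of oxygen for sulfur in the five-membered aromatic ring has neither size nor direction. Thiophen-2-yl stays well apart from the two groups with nitrogen in the ring, with an at least 26-fold lower number from compound 1 to compound 4 (1.42 log units; beyond the scatter) and an at least 2.9-fold lower number from compound 2 to compound 4 (0.46 log units; beyond the scatter).

The compounds shown leave open how compound 3 and compound 4 actually compare. Also open, on these data alone, is whether pyridin-3-yl, morpholin-4-yl or a longer chain carrying pyridin-4-yl in this place would give a number in this assay.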